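The source may hold more compounds than are shown below. What is called first, only, known or untested is meant among the compounds shown, and "the series" means these compounds.

Three measured compounds share one core: compound 1 `CC(C)(C)OC(=O)NC1CCCN(C(=O)CN2CN(c3ccccc3)C3(CCN(C(=O)c4ccc(C5CCCCC5)cc4)CC3)C2=O)C1`, compound 2 `CC(C)(C)c1ccc(C(=O)N2CCC3(CC2)C(=O)N(CC(=O)N2CCCC(C(N)=O)C2)CN3c2ccccc2)cc1` and compound 3 `O=C(CN1CN(c2ccccc2)C2(CCN(C(=O)c3ccc(C4CCCCC4)cc3)CC2)C1=O)NCCO`. In an assay on HEK293 cells for displacement of a labelled ligand from NPC1-like intracellular cholesterol transporter 1 (Homo sapiens) (on this read-out lower numbers stand for stronger inhibition and higher numbers for weaker inhibition), compound 1 gives 4400 nM, compound 3 gives 2000 nM and compound 2 gives 16900 nM. Compound 2 thus holds the highest number of the three, with compound 1 the nearest and compound 3 the furthest below it, both gaps beyond the scatter. Compound 4 `CC(C)(C)c1ccc(C(=O)N2CCC3(CC2)C(=O)N(CC(=O)NCCCN)CN3c2ccccc2)cc1` is not yet measured and differs from compound 2 in one place: (3-aminopropyl)amino in place of 3-carbamoylpiperidin-1-yl on a carbonyl carbon. Among the measured compounds shown here, no measured pair shows this exact change. Since compound 3 reaches 2000 nM on the same core, a move toward lower numbers is expected, though a modest one. The expected step is a 2.8-fold lower number from compound 2 to compound 4 (0.45 log units; beyond the scatter). Compound 4 is estimated at 6000 nM, in the range 2000 nM to 20000 nM.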

Compound 4, half-maximal inhibitory concentration: 4200 nM
Compound 4: the middle estimate sits 1.4-fold (0.15 log units) above what was measured, within the range that was stated.
By their numbers in this assay, from the lowest: compound 3; then compounds 4 and 1 (each within the scatter of the next); then compound 2.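

In this assay, among the compounds shown here, (3-aminopropyl)amino in place of 3-carbamoylpiperidin-1-yl on a carbonyl carbon gives a 4.0-fold lower number from compound 2 to compound 4 (0.60 log units; beyond the scatter), the first one-place reading at this position. It shows that the six-membered ring is not needed there for a lower number, and that an open chain ending in an amine is accepted. Nothing shown accounts for the step.

As far as these compounds go, it remains open whether the terminal amine matters or the loss of the ring alone is enough. A hydroxyl, a carboxylic acid or a longer chain at this position could separate the two.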